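Replacing naphthalen-2-yl with 2-chlorophenyl in compound 3

A few compounds are considered here, and "the series" means these few. Any claim that something is new, unique, unknown or untested is made for them only; others in the source may bear on it.

Measured in a functional assay on SW-620 cells (Homo sapiens) for cytotoxicity, read by MTT assay, with stated times of 4 h and 72 h, tested at 2 uM; on this read-out higher numbers stand for weaker inhibition and lower numbers for stronger inhibition:
- compound 1 `Cc1cc(Nc2ccc(C(=O)/C=C/c3ccc4ccccc4c3)cc2)n2nc(SCc3cccc4ccccc34)nc2n1`: 68 nM
- compound 2 `Cc1cc(Nc2ccc(C(=O)/C=C/c3ccc4ccccc4c3)cc2)n2nc(SC(=O)c3csc4ccc(Cl)cc34)nc2n1`: 35 nM
- compound 3 `Cc1cc(Nc2ccc(C(=O)/C=C/c3ccc4ccccc4c3)cc2)n2nc(SCc3nc4ccccc4[nH]3)nc2n1`: 5 nM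

Compound 3 holds the lowest of the three numbers, beyond the scatter from both others: a 14-fold lower number from compound 1 to compound 3 (1.13 log units; beyond the scatter), and a 7.0-fold lower number from compound 2 to compound 3 (0.85 log units; beyond the scatter). Compound 4 `Cc1cc(Nc2ccc(C(=O)/C=C/c3ccccc3Cl)cc2)n2nc(SCc3nc4ccccc4[nH]3)nc2n1` differs from compound 3 at another place: 2-chlorophenyl in place of naphthalen-2-yl on a double-bonded chain carbon bound to a double-bonded chain carbon. Going by the values given here, all measured steps change the group on the sulfur, so no measured step tests this change directly. With compound 3 already at 5 nM, a modest move toward a higher number is expected in this assay, an expected 3.0-fold higher number from compound 3 to compound 4 (0.48 log units; beyond the scatter). For compound 4 the estimate is 15 nM, with an estimated range of 3 nM to 70 nM.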

Compound 4, half-maximal inhibitory concentration: 680 nM
For compound 4 the middle estimate is 45-fold (1.66 log units) below the measured one, and the stated range ends below it.
By their numbers in this assay, from the lowest: compound 3; then compounds 2 and 1 (each within the scatter of the next); then compound 4.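

In this assay, the group on the double-bonded chain carbon matters greatly: with 2-chlorophenyl in place of naphthalen-2-yl, the result is a 140-fold higher number from compound 3 to compound 4 (2.13 log units; beyond the scatter), a larger step than any among the changes on the sulfur. Going by these compounds alone, this place, untested by the earlier compounds, therefore moves the number more than those changes do. Nothing available bears on why the number rises.

From the compounds shown here alone, whether the rise follows the loss of the second aromatic ring or the arrival of the chlorine stays open; an unsubstituted phenyl would separate the two. Going by these compounds, whether the step keeps its size with (naphthalen-1-yl)methyl on the sulfur is also open.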